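The source may report more compounds than this note shows. Statements on the series, on what has been measured and on what is new or still open speak of the compounds shown alone.

Measured compounds and their values:
compound 1 `CCCCCCCCOc1ccc2c(=O)c(Cc3c(OC(C)=O)ccc4c(C)cc(=O)oc34)c(N(CC)CC)oc2c1` — > 100000 nM
compound 2 `CCN(CC)c1oc2cc(OC)ccc2c(=O)c1Cc1c(OC(C)=O)ccc2ccc(=O)oc12` — 83000 nM
compound 3 `Cc1[nH]c2ccccc2c1Cc1c(OC(=O)CCCC(=O)O)ccc2c(C)cc(=O)oc12` — 29000 nM

In an ADME assay on MT4 cells (Homo sapiens) for cytotoxicity, read by MTT assay, with a stated time of 96 h (on this read-out lower numbers stand for higher toxicity in this test and higher numbers for lower toxicity in this test), compound 1 gives no number but only a limit, > 100000 nM. Compound 1 therefore stands at the limit of > 100000 nM in this assay, at which 1 of the 3 values shown sits, so its true position is not fixed. Compound 2 gives 83000 nM in this assay. Compound 3 gives 29000 nM in this assay, the lowest of the three numbers shown.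

Compound 4 `CCN(CC)c1oc2cc(OC(C)=O)ccc2c(=O)c1Cc1c(OC(C)=O)ccc2c(C)cc(=O)oc12` has not been measured. It differs from compound 1 in one place: acetyl in place of octyl on an oxygen on an aromatic ring. For the measured compounds named here, no measured pair in this set covers this exchange, so the size of the step can only be expected, not read off. Since all three measured compounds sit at high concentrations in this assay, the expected step from compound 1 to compound 4, an at least 1.1-fold lower number from compound 1 to compound 4 (0.04 log units; that floor lies within the scatter), is one that stays within the usual scatter, with no clear direction. Compound 4 is accordingly estimated at 90000 nM, with a range from 30000 nM to 250000 nM, and a real chance that only a limit is reported again.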

Compound 4, half-maximal cytotoxic concentration: 44000 nM
Beside the measured number, compound 4's estimate is 2.0-fold (0.31 log units) above it; low and high end bracket the measured number.
By their numbers in this assay, from the lowest: compounds 3, 4 and 2 (each within the scatter of the next, the first and the last beyond it). At a limit, above all of these: compound 1.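

In this assay, for the compounds shown here, acetyl in place of octyl on an oxygen on an aromatic ring gives an at least 2.2-fold lower number from compound 1 to compound 4 (0.35 log units; beyond the scatter), the first step in this set that can be read at this position, and it shows that the read-out responds to the group on this oxygen. Compound 1 gives only a limit, > 100000 nM, and not a number. The step is therefore a floor and not a full size, because compound 1 sits at that limit: the limit of > 100000 nM in this assay, at which 1 of the 4 values shown sits.

The compounds shown leave open whether the step follows the octyl chain leaving or the acetyl entering, as the two changes come together in this one pair. Going by these compounds, how a free hydroxyl, a butyl chain or an amine on this oxygen would read in this assay also remains open.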